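A few compounds are considered here, and "the series" means these few. Any claim that something is new, unique, unknown or untested is made for them only; others in the source may bear on it.

In an ADME assay on microsomes from liver (Homo sapiens) for metabolic stability, with a stated time of 10 min (a higher number here means that more of the compound is left, a lower number that less of the compound is left), compound 2, whose structure is `COc1cc(OCc2cccc(C#N)c2)c2cc(-c3cn4nc(OC)sc4n3)oc2c1`, gives 100%, the highest of the three numbers that have been measured. Compound 1, with the structure `COc1cc(OCc2cccc(CCc3ccccc3)c2)c2cc(-c3cn4nc(OC)sc4n3)oc2c1`, gives 99% in this assay, and the step of a number 1 percentage points higher from compound 1 to compound 2 (within the scatter) stays within the scatter, so the two compounds cannot be told apart. Compound 3, with the structure `COc1cc(OCc2cccc(Oc3ccccc3)c2)c2cc(-c3cn4nc(OC)sc4n3)oc2c1`, gives 86% in this assay, and the step of a number 14 percentage points lower from compound 2 to compound 3 (beyond the scatter) lies beyond the scatter, as does the step of a number 13 percentage points lower from compound 1 to compound 3 (beyond the scatter).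

Compound 4 is the structure `COc1cc(OCc2ccccc2OC)c2cc(-c3cn4nc(OC)sc4n3)oc2c1` and has not been measured. Its change from compound 2 is 2-methoxyphenyl in place of 3-cyanophenyl on a saturated chain carbon bound to an oxygen on an aromatic ring. For the measured compounds named here, no measured step covers a methoxyphenyl group; the two steps that bear on it show that one exchange at this position left the number unchanged, while another lowered it modestly. Because compound 2 gives 100% in this assay, close to the top of what can be read, the most that seems possible is a modest drop of the size seen for compound 3, and no change is also possible. Compound 4 is therefore expected to give 94% in this assay, with a range from 84% to 100%, which means an expected step of a number 6 percentage points lower from compound 2 to compound 4 (within the scatter).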

Compound 4, percent of the compound remaining: 82%
Compound 4: middle estimate off by 12 percentage points, on the high side; measured number outside the range, below it.
By their numbers in this assay, from the lowest: compounds 4 and 3 (each within the scatter of the next); then compounds 1 and 2 (each within the scatter of the next).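

In this assay, 2-methoxyphenyl in place of 3-cyanophenyl gives a number 18 percentage points lower from compound 2 to compound 4 (beyond the scatter), so a clear fall at this position does not require a larger group: the two groups entering and leaving have the same count of heavy atoms and the same count of hydrogen-bond acceptors. Earlier, the only clear fall came with the longer phenoxy-bearing group of compound 3, at 86%, whereas compound 4, at 82%, lies within the scatter of it, and compound 1, with its phenethyl group, stays at 99%, which goes against any simple link between group size and this number. Nothing shown here explains why the number falls in compound 4.

The change from 3-cyanophenyl to 2-methoxyphenyl swaps the nitrile for a methoxy group and also alters the numbered place of that group on the ring, so the compounds shown cannot say which of the two matters. From the compounds shown here alone, how the number would respond to an amine or a carboxylic acid on this ring, or to a longer chain between the ring and the oxygen, also remains open.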